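Phenyl in place of methyl on a ring amine nitrogen

The source may hold more compounds than are shown below. What is called first, only, known or untested is meant among the compounds shown, and "the series" means these compounds.

Among the compounds with values here, in a functional assay on HL-60 cells (Homo sapiens) for cytotoxicity, read by MTT assay, with a stated time of 24 h (on this read-out higher numbers stand for weaker inhibition and lower numbers for stronger inhibition), compound 1 (`BrCCCCOc1c(Br)cc(Br)cc1Oc1ccc(Br)cc1Br`) gives 25.9 ug/mL while compound 2 (`CN1CCN(CCCCCOc2c(Br)cc(Br)cc2Oc2ccc(Br)cc2Br)CC1`) gives 48.3 ug/mL and so stands within the scatter of the only other number available. Compound 3 (`Brc1ccc(Oc2cc(Br)cc(Br)c2OCCCCCN2CCN(c3ccccc3)CC2)c(Br)c1`) has phenyl in place of methyl on an amine nitrogen in a ring and otherwise matches compound 2. Within the data shown here, only one measured step bears on this change. That step, a 1.9-fold higher number from compound 1 to compound 2 (0.27 log units; within the scatter) and within the scatter, brought in the (4-methylpiperazin-1-yl)methyl group but did not vary the group on that nitrogen. The data therefore give only indirect guidance, and no step beyond the scatter is expected in this assay here. The estimated change, a 1.2-fold lower number from compound 2 to compound 3 (0.08 log units; within the scatter), is small and within the scatter. Compound 3 is expected at 40 ug/mL with an estimated range from 16 ug/mL as its lower end to 90 ug/mL as its upper end.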

Compound 3, half-maximal inhibitory concentration: 41.6 ug/mL
Compound 3: the middle estimate sits 1.0-fold (0.02 log units) below what was measured; the measured number falls inside the stated range.
By their numbers in this assay, from the lowest: compounds 1, 3 and 2 (each within the scatter of the next).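

In this assay the change from methyl to phenyl on the amine nitrogen in a ring gives a 1.2-fold lower number from compound 2 to compound 3 (0.06 log units; within the scatter) and is the first step among these compounds to vary the group at this position. The entering group brings one six-membered aromatic ring of carbon only and 6 heavy atoms where methyl had 1 heavy atom, yet the step stays within the scatter, so this added size and ring leave no readable mark on the number. No measurement bearing on why this is so is available. The compounds shown leave open how a benzyl or an acetyl group on this nitrogen, or a plain hydrogen there, would read in this assay. They also leave open whether a phenyl carrying a methoxy group would read any differently from the plain phenyl.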